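Compound 3 and a difluoromethoxy swap for cyano

The source may hold more compounds than are shown below. What is called first, only, known or untested is meant among the compounds shown, and "the series" means these compounds.

Values in an ADME assay on microsomes from liver (Homo sapiens) for metabolic stability, read by LC-MS, with a stated time of 1 h; a higher number here means that more of the compound is left, a lower number that less of the compound is left:
- compound 1 `O=[N+]([O-])c1cn2c(n1)OC[C@@H](OCc1ccc(-c3cccc(OCc4ccccc4)c3)cc1)C2`: 64%
- compound 2 `O=[N+]([O-])c1cn2c(n1)OC[C@@H](OCc1ccc(-c3ccc(CNc4ccccc4)cc3)cc1)C2`: 12%
- compound 3 `N#Cc1ccc(-c2ccc(CO[C@@H]3COc4nc([N+](=O)[O-])cn4C3)cc2)cc1`: 95%

Compound 3 holds the highest number of the three at 95%. Compound 1 lies nearest to it at 64%, and compound 2 lies furthest at 12%. Both gaps are beyond the scatter.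

The next structure is compound 4 `O=[N+]([O-])c1cn2c(n1)OC[C@@H](OCc1ccc(-c3ccc(OC(F)F)cc3)cc1)C2`, with difluoromethoxy in place of cyano on an aromatic carbon. Within the data shown here, one measured step bears on this change: a number 83 percentage points higher from compound 2 to compound 3 (beyond the scatter). It shows that the read-out in this assay can move a long way when the cyano group is exchanged for another group. However, it involves anilinomethyl, and no compound with difluoromethoxy has been measured, so it gives no direct size for this step. A step as large as that one is not expected here, since compound 4 carries no anilinomethyl. Compound 3 at 95% also leaves little room for a rise, so any change is likely to be downward.

The expected move is a number 10 percentage points lower from compound 3 to compound 4 (within the scatter), an estimated drop of modest size. The estimate for compound 4 is 85%, with an expected range from 63% to 98%.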

Compound 4, percent of the compound remaining: 94%
Estimate against measurement, compound 4: 9 percentage points below, within the range that was stated.
By their numbers in this assay, from the lowest: compound 2; then compound 1; then compounds 4 and 3 (each within the scatter of the next).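

In this assay, the step of a number 1 percentage points lower from compound 3 to compound 4 (within the scatter) shows that at this place, on an aromatic carbon of a six-membered aromatic ring of carbon only and para to a large group, the 4-cyanophenyl of compound 3 and the 4-(difluoromethoxy)phenyl of compound 4 cannot be told apart, even though the entering group has 4 heavy atoms and the leaving one has 2. The step of a number 82 percentage points higher from compound 2 to compound 4 (beyond the scatter) then adds a second group to cyano that stands far from anilinomethyl at this place, where the earlier compounds had shown this only for cyano through the step of a number 83 percentage points higher from compound 2 to compound 3 (beyond the scatter). No evidence is available that bears on this result.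

The compounds shown leave open whether an amine, a carboxylic acid or a longer chain at this same place would read close to compound 3 at 95% or close to compound 2 at 12%. They also leave open whether difluoromethoxy would read the same way on another aromatic carbon of that ring.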